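A few compounds are considered here, and "the series" means these few. Any claim that something is new, unique, unknown or untested is made for them only; others in the source may bear on it.

In a functional assay on K562 cells (Homo sapiens) for cytotoxicity, read by sulforhodamine B assay (on this read-out lower numbers stand for stronger inhibition of growth and higher numbers for weaker inhibition of growth), compound 1 `CC1=CC[C@@H]([C@@](C)(O)CCCC(C)(C)NC=S)CC1` gives 16700 nM, and compound 2 `CC1=CC[C@@H]([C@@](C)(O)CCCC(C)(C)NC(=S)NN)CC1` gives 20 nM, the lower of the two numbers recorded, with the step of an 840-fold lower number from compound 1 to compound 2 (2.92 log units; beyond the scatter). Compound 2 therefore stands as the stronger of the two measured compounds in this assay, separated from compound 1 by a step beyond the scatter.

Compound 3 `CC1=CC[C@@H]([C@@](C)(O)CCCC(C)(C)NC(=S)N/N=C\c2ccccc2)CC1` is the unmeasured member of the series. It differs from compound 2 by a group of 8 heavy atoms (7 carbon, 1 nitrogen; one six-membered aromatic ring of carbon only) in place of one nitrogen atom, on an amide-type nitrogen. Among the measured compounds shown here, the only measured step, from compound 1 to compound 2, concerns the thiocarbonyl carbon rather than the amide-type nitrogen, so it does not bear directly on the change from compound 2 to compound 3; it shows only that this part of the molecule can move the number in this assay by a large amount. For the measured compounds named here, no measured pair reports what the added group does. Compound 3 is therefore expected to stay close to compound 2, with an estimated step of a 1.5-fold higher number from compound 2 to compound 3 (0.18 log units; within the scatter) that would lie within the scatter. The estimated value for compound 3 in this assay is 30 nM, with a range from 5 nM to 200 nM.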

Compound 3, concentration for 50% growth inhibition: 130 nM
Compound 3: the middle estimate sits 4.3-fold (0.64 log units) below what was measured; low and high end bracket the measured number.
By their numbers in this assay, from the lowest: compound 2; then compound 3; then compound 1.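

In this assay, the group of 8 heavy atoms with its six-membered aromatic ring, placed on the amide-type nitrogen in place of the amino group, gives a 6.5-fold higher number from compound 2 to compound 3 (0.81 log units; beyond the scatter), so this position does respond to the change, by a modest step beyond the scatter. Among the compounds shown here, the same group does not cancel what the earlier step gained: set against the hydrogen on the thiocarbonyl carbon of compound 1, the whole group in its place gives a 130-fold lower number from compound 1 to compound 3 (2.11 log units; beyond the scatter), a large step, though the amino-bearing compound 2 remains the one with the lowest number of the three. No evidence is available on why the number rises with this change.

The compounds shown leave open whether the rise belongs to the aromatic ring itself or to the double bond outside it, and how much of the large step survives with other groups at this nitrogen. A methyl group in place of the aromatic ring, or a pyridine ring in its place, would help to separate these readings.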